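The source may hold more compounds than are shown below. What is called first, only, known or untested is meant among the compounds shown, and "the series" means these compounds.

Measured compounds:
- Compound 1 `COc1ccc(/C=C\c2cc(OC)c(OC)c(OC)c2)cc1OCc1ccc(CN[C@H](C(=O)O)[C@H](C)O)cc1` — in a functional assay on HepG2 cells (Homo sapiens) for antiproliferative activity, read by CCK-8 assay, with a stated time of 48 h (a higher number here means a weaker inhibitor, a lower number a stronger inhibitor), compound 1 gives > 10000 nM, which is a limit of the assay rather than a number.
- Compound 2 `COc1ccc(/C=C\c2cc(OC)c(OC)c(OC)c2)cc1OCc1ccc(CN2CCCCC2C(=O)NCCN)cc1` — in this assay compound 2 gives 4800 nM.
- Compound 3 `COc1ccc(/C=C\c2cc(OC)c(OC)c(OC)c2)cc1OCc1ccc(C=O)cc1` — in this assay compound 3 gives 800 nM.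

Compound 3 stands lowest of the two numbers shown; its nearest neighbour is compound 2, with a number higher by a margin that lies beyond the scatter. Compound 1 sits at the limit (the limit of > 10000 nM in this assay, at which 1 of the 3 values shown sits).

The step now followed leads from compound 3 to compound 4 `COc1ccc(/C=C\c2cc(OC)c(OC)c(OC)c2)cc1OCc1ccc(CNCCN(C)C)cc1`. The change is ((2-(dimethylamino)ethyl)amino)methyl in place of formyl on an aromatic carbon. For the measured compounds named here, two measured steps bear on it, both departing from the same aminomethyl-bearing compound: an at least 2.0-fold lower number from compound 1 to compound 2 (0.31 log units; beyond the scatter) and an at least 12-fold lower number from compound 1 to compound 3 (1.09 log units; beyond the scatter). Both show that the compounds carrying a basic amine at this position, compound 1 and compound 2, give higher numbers in this assay than the formyl-bearing compound 3, with the step to compound 3 the larger. Compound 4 again carries an amine at that position, so the expectation is a higher number than compound 3.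

The estimate for compound 4 is a step of a 3.8-fold higher number from compound 3 to compound 4 (0.57 log units; beyond the scatter) in this assay, toward a weaker inhibitor. Compound 4 is therefore expected to give 3000 nM, within a range from 1000 nM to 10000 nM.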

Compound 4, half-maximal inhibitory concentration: 4400 nM
The estimate for compound 4 lay 1.5-fold (0.17 log units) below the measured number; low and high end bracket the measured number.
By their numbers in this assay, from the lowest: compound 3; then compounds 4 and 2 (each within the scatter of the next). At a limit, above all of these: compound 1.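

In this assay, the step of a 5.5-fold higher number from compound 3 to compound 4 (0.74 log units; beyond the scatter) shows, with a number at both ends, that placing ((2-(dimethylamino)ethyl)amino)methyl instead of formyl on this aromatic carbon gives a weaker inhibitor, which the earlier step from compound 1 to compound 3 could show only against a limit. The two amine groups on the saturated chain carbon are not told apart, with a 1.1-fold lower number from compound 2 to compound 4 (0.04 log units; within the scatter), so the open chain and the piperidine amide give numbers within the scatter of each other. Putting 2-(dimethylamino)ethyl in place of 1-carboxy-2-hydroxypropyl on the amine nitrogen gives an at least 2.2-fold lower number from compound 1 to compound 4 (0.35 log units; beyond the scatter), which is only a bound, since compound 1 stands at a limit of the assay: the limit of > 10000 nM in this assay, at which 1 of the 4 values shown sits.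

The compounds shown leave open whether a small group such as hydroxymethyl, acetyl or a plain aminomethyl at this place would stay near compound 3 or fall with compound 2 and compound 4. They also leave open whether a longer chain between the two nitrogens, or a carboxylic acid without the hydroxyl on the amine nitrogen, would shift the number from that of compound 4.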